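Swapping chloro for methoxy in compound 3

The source may hold more compounds than are shown below. What is called first, only, known or untested is meant among the compounds shown, and "the series" means these compounds.

Measured in a functional assay on HepG2 cells (Homo sapiens) for inhibition, read by MTT assay, with a stated time of 72 h; on this read-out lower numbers stand for stronger inhibition and higher numbers for weaker inhibition:
- compound 1 `Cc1cc2occ(-c3nc(-c4ccccc4)c(-c4ccccc4)n3-c3ccc(Cl)cc3)c(=O)c2cc1Cl`: 1560 nM
- compound 2 `Cc1ccc(-n2c(-c3coc4cc(C)c(Cl)cc4c3=O)nc(-c3ccccc3)c2-c2ccccc2)cc1`: 6250 nM
- compound 3 `Cc1cc2occ(-c3nc(-c4ccccc4)c(-c4ccccc4)n3-c3cccc(Cl)c3)c(=O)c2cc1Cl`: 25000 nM

Of these three, compound 3 gives the highest number, 25000 nM. It lies beyond the scatter from both others, with a 4.0-fold higher number from compound 2 to compound 3 (0.60 log units; beyond the scatter) and a 16-fold higher number from compound 1 to compound 3 (1.20 log units; beyond the scatter).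

Compound 4 `COc1cccc(-n2c(-c3coc4cc(C)c(Cl)cc4c3=O)nc(-c3ccccc3)c2-c2ccccc2)c1` has not yet been measured. It carries methoxy in place of chloro on an aromatic carbon, meta to a large group: methoxy in place of chloro on an aromatic carbon. The same difference reads 3-chlorophenyl to 3-methoxyphenyl.

Within the data shown here, no measured compound carries methoxy, so the evidence is indirect. The closest case is the modest 4.0-fold higher number from compound 1 to compound 2 (0.60 log units; beyond the scatter), which also replaces chloro on an aromatic carbon, though in 4-chlorophenyl. The large 16-fold higher number from compound 1 to compound 3 (1.20 log units; beyond the scatter) shows that this series can respond strongly in this assay to changes on this ring. A small upward move, not beyond the scatter, is therefore expected. The expected change is a 1.2-fold higher number from compound 3 to compound 4 (0.08 log units; within the scatter). For compound 4 the estimated value is 30000 nM, with an expected range of 10000 nM to 80000 nM.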

Compound 4, half-maximal inhibitory concentration: 6250 nM
The estimate for compound 4 lay 4.8-fold (0.68 log units) above the measured number, and the stated range ends above it.
By their numbers in this assay, from the lowest: compound 1; then compounds 2 and 4 (each within the scatter of the next); then compound 3.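

In this assay, the group at this place on the ring matters as well as the place itself: methoxy in place of chloro, meta to a large group, recovers part of what the 3-chlorophenyl ring loses (a 4.0-fold lower number from compound 3 to compound 4 (0.60 log units; beyond the scatter)). The 3-methoxyphenyl ring reads the same as the 4-methylphenyl ring within the scatter (no change at the digits printed from compound 2 to compound 4 (within the scatter)), while the 4-chlorophenyl ring still gives the lower number (a 4.0-fold higher number from compound 1 to compound 4 (0.60 log units; beyond the scatter)). The data shown offer no explanation for these differences.

The compounds shown leave open how an amine, a hydroxyl group or a longer alkoxy chain would read at this place on the ring. They also leave open whether methoxy in place of chloro would give a similar step on a different core.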